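Cyclopentyl to isopropyl on the shared aminopyrimidine core

The source may hold more compounds than are shown below. What is called first, only, known or untested is meant among the compounds shown, and "the series" means these compounds.

Compound 3 `NS(=O)(=O)c1ccc(Nc2ncc(/N=C/c3ccc(C(F)(F)F)cc3)c(NC3CCCC3)n2)cc1` gives 21900 nM in a functional assay on HeLa cells (Homo sapiens) for antiproliferative activity, read by MTT assay; a lower number here means a stronger inhibitor, a higher number a weaker inhibitor. Of the two numbers in hand it is the highest; its nearest neighbour is compound 2 `NS(=O)(=O)c1ccc(Nc2ncc(/N=C/c3cccs3)c(NC3CCCC3)n2)cc1` with 10900 nM, and the step of a 2.0-fold higher number from compound 2 to compound 3 (0.30 log units; within the scatter) sits inside the scatter. Compound 1 `CN1CCN(c2ccc(Nc3ncc(/N=C/c4ccc(C(F)(F)F)cc4)c(NC4CCCC4)n3)cc2)CC1` reports only a limit, > 100000 nM. The step of an at least 4.5-fold lower number from compound 1 to compound 3 (0.65 log units; beyond the scatter) is therefore bounded by the limit of > 100000 nM in this assay, at which 1 of the 3 values shown sits, and is at least modest.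

Compound 4 `CC(C)Nc1nc(Nc2ccc(S(N)(=O)=O)cc2)ncc1/N=C/c1ccc(C(F)(F)F)cc1` differs from compound 3 in one place: isopropyl in place of cyclopentyl on a nitrogen on an aromatic ring. Going by the values given here, neither measured step touches this nitrogen; one changes the group on the aromatic carbon, the other the group on the carbon with the double bond to nitrogen, so no measured step bears directly on the change. Among the compounds with values here, with no precedent, the expectation for compound 4 is a modest move of a 1.8-fold higher number from compound 3 to compound 4 (0.26 log units; within the scatter), direction uncertain, with the number falling between 12000 nM and 130000 nM. The estimate for compound 4 in this assay is 40000 nM.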

Compound 4, half-maximal inhibitory concentration: > 100000 nM
Compound 4 gave a limit, no number; the forecaster's own chance of this, stated with the estimate: 25%; at least 2.5-fold (0.39 log units) between middle value and limit.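

Going by these compounds alone, this nitrogen on an aromatic ring is the first place among the sulfamoyl compounds where a single change moves the read-out beyond the scatter, with an at least 4.5-fold higher number from compound 3 to compound 4 (0.65 log units; beyond the scatter) in this assay. As far as these compounds go, compound 4 gives only a limit and no number, so this step has a lower bound and its full size stays unknown. With the sulfamoyl group kept, the change from cyclopentyl to isopropyl is enough to reach the limit otherwise shown only by the 4-methylpiperazin-1-yl compound: the limit of > 100000 nM in this assay, at which 2 of the 4 values shown sit.

From the compounds shown here alone, whether the ring itself or the carbon count matters stays open, and a cyclobutyl or cyclohexyl group or an open pentyl chain on this nitrogen would separate the two. Also open, going by these compounds, is whether isopropylamino has the same outcome with the thiophen-2-yl group of compound 2.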